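The source may hold more compounds than are shown below. What is called first, only, known or untested is meant among the compounds shown, and "the series" means these compounds.

Compound 1 `COc1ccc2[nH]c(=O)c(-c3nc4cc(C)c(C)cc4[nH]3)cc2c1` was tested in a functional assay on NCI-H460 cells (Homo sapiens) for cytotoxicity, read by MTT assay, with a stated time of 48 h; a higher number here means a weaker inhibitor, a lower number a stronger inhibitor. In this assay compound 1 gives only a limit, > 100000 nM, and no number. Its companion compound 2 `COc1ccc2[nH]c(=O)c(-c3nc4ccccc4[nH]3)cc2c1` is built on the same core with the substituents on the fused five-membered ring removed. In this assay compound 2 likewise reaches only the limit, > 100000 nM. So compound 1 stands nowhere that can be ranked: both values sit at the limit of > 100000 nM in this assay, at which 2 of the 2 values shown sit, and neither compound separates from the other.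

The step to compound 3 `Cc1ccc2[nH]c(=O)c(-c3nc4cc(C)c(C)cc4[nH]3)cc2c1` is a single change on the core of compound 1 (methyl in place of methoxy on an aromatic carbon), methyl in place of methoxy on an aromatic carbon. Going by the values given here, no measured pair shows what this change does here, so no direction can be read from the data. Since compound 1 gives > 100000 nM and compound 2 gives > 100000 nM, the shared core appears to carry no measurable cytotoxicity, and a step that the limit leaves unreadable from compound 1 to compound 3 is expected, which is none beyond the scatter. Compound 3 is therefore expected to give about 150000 nM in this assay, in the range 50000 nM to 500000 nM, most likely reported again as a limit.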

Compound 3, half-maximal inhibitory concentration: > 100000 nM
Compound 3: only a limit was reported; the forecaster's own chance of this, stated with the estimate: 80%; the middle value does not contradict the limit.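

No step from compound 1 to compound 3 can be read in this assay, because each compound shown gives only a limit: the limit of > 100000 nM in this assay, at which 3 of the 3 values shown sit. The compounds shown leave open whether methyl in place of methoxy on an aromatic carbon has any effect, and whether any compound on the shared core gives a number.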